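The source may hold more compounds than are shown below. What is called first, only, known or untested is meant among the compounds shown, and "the series" means these compounds.

Measured compounds in a functional assay on A549 cells (Homo sapiens) for inhibition, read by sulforhodamine B assay, with a stated time of 48 h; a higher number here means a weaker inhibitor of growth, a lower number a stronger inhibitor of growth:
- compound 1 `O=C(Nc1cccc(-n2cc(-c3ccncc3)c(-c3ccc(Cl)c(O)c3)n2)c1)Nc1cccc(C(F)(F)F)c1`: 1370 nM
- compound 2 `O=C(Nc1cccc(-n2cc(-c3ccncc3)c(-c3ccc(Cl)c(O)c3)n2)c1)Nc1ccc(Cl)c(Cl)c1`: 1010 nM
- compound 3 `COc1cc(-c2nn(-c3cccc(NC(=O)Nc4ccc(Cl)c(C(F)(F)F)c4)c3)cc2-c2ccncc2)ccc1Cl`: 1020 nM

All three share the same core and differ only in the groups hung on it. Compound 3 stands second highest of the three numbers, but its nearest neighbour is compound 2, and even its furthest, compound 1, lies within the scatter of it, so the three cannot be placed in any order. Within the data shown here, the one measured step, a 1.4-fold lower number from compound 1 to compound 2 (0.13 log units; within the scatter), swaps the aryl group on the urea nitrogen and stays within the scatter.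

Compound 4 `O=C(Nc1cccc(-n2cc(-c3ccncc3)c(-c3ccc(Cl)c(O)c3)n2)c1)Nc1ccc(Cl)c(C(F)(F)F)c1` arises from compound 3 by one change: hydrogen in place of methyl on an oxygen on an aromatic ring. Among the measured compounds shown here, no measured step covers this change, since compound 3 differs from compounds 1 and 2 in two places at once. What can be said is that compounds 1 and 2, which already carry the hydroxy group, give numbers indistinguishable from compound 3. A step for compound 4 of about a 1.0-fold lower number from compound 3 to compound 4 (0.01 log units; within the scatter) is therefore expected, none beyond the scatter. Compound 4 is estimated at 1000 nM, between 450 nM and 2200 nM.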

Compound 4, concentration for 50% growth inhibition: 927 nM
Compound 4: the middle estimate sits 1.1-fold (0.03 log units) above what was measured; the range from low to high includes it.
By their numbers in this assay, from the lowest: compounds 4, 2, 3 and 1 (each within the scatter of the next).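

In this assay, methoxy to hydroxy on the 4-chloro-3-methoxyphenyl group now has a direct reading of its own, a 1.1-fold lower number from compound 3 to compound 4 (0.04 log units; within the scatter), so at this oxygen the methyl and the hydrogen cannot be told apart. The aryl group on the urea adds two more one-place comparisons: trifluoromethyl in place of chloro gives a 1.1-fold lower number from compound 2 to compound 4 (0.04 log units; within the scatter), and chloro in place of hydrogen gives a 1.5-fold lower number from compound 1 to compound 4 (0.17 log units; within the scatter), so neither of these changes separates its pair of compounds either. Nothing measured here gives a reason for these results.

Going by these compounds, whether a larger group on this oxygen, such as a longer chain like butyl, would move the number beyond the scatter remains open. So does the outcome of replacing the hydroxy with an amine or a carboxylic acid.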